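This account rests on a few compounds, and the source may have more. Where it says the series, first, only, none or still open, it means among the compounds named here.

Compound 1, `COc1ccc(C(=O)/C=C/c2ccc(OCc3cn(Cc4ccccc4)nn3)cc2)cc1`, in a functional assay on A549 cells (Homo sapiens) for cytotoxicity, read by MTT assay, with a stated time of 48 h; a higher number here means a weaker inhibitor, a lower number a stronger inhibitor: 11000 nM
Compound 2, `COc1ccc(C(=O)/C=C/c2ccc(OCc3cn(Cc4cccc(Br)c4)nn3)cc2)cc1`, in this assay: 15000 nM

Compound 2 has the higher of the two numbers, yet the gap to compound 1 is within the scatter: a 1.4-fold higher number from compound 1 to compound 2 (0.13 log units; within the scatter). Compound 3, `COc1ccc(C(=O)/C=C/c2ccc(OCc3cn(Cc4cccc(F)c4)nn3)cc2)cc1`, is not yet measured; it differs from compound 2 by fluoro in place of bromo on an aromatic carbon. Going by the values given here, the only measured step that bears on this is the one that brought the bromine in, a 1.4-fold higher number from compound 1 to compound 2 (0.13 log units; within the scatter), and it stayed within the scatter. Exchanging that bromine for fluorine is therefore expected to move this assay little, in no clear direction. Compound 3 is thus estimated at 12000 nM, between 5000 nM and 28000 nM, an expected step of a 1.3-fold lower number from compound 2 to compound 3 (0.10 log units; within the scatter).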

Compound 3, half-maximal inhibitory concentration: 9000 nM
For compound 3 the middle estimate is 1.3-fold (0.12 log units) above the measured one, and the stated range covers the measured number.
By their numbers in this assay, from the lowest: compounds 3, 1 and 2 (each within the scatter of the next).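

On this benzyl ring, exchanging bromo for fluoro moves the number in this assay only slightly (a 1.7-fold lower number from compound 2 to compound 3 (0.22 log units; within the scatter)), and fluoro in place of hydrogen does the same (a 1.2-fold lower number from compound 1 to compound 3 (0.09 log units; within the scatter)). Hydrogen, bromo and fluoro at this place therefore cannot be told apart in this assay, which the single earlier step could not show for a second halogen. Nothing available gives a reason for this. Going by these compounds, whether an amine or a carboxylic acid at this place would shift the number beyond the scatter remains open, as does the effect of these halogens elsewhere on the ring.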